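A few compounds are considered here, and "the series" means these few. Any claim that something is new, unique, unknown or untested is made for them only; others in the source may bear on it.

Measured in an ADME assay (liver) for metabolic stability, with Liver microsome (Rattus norvegicus) as the target, read by LC-MS, using microsomes, with a stated time of 30 min, tested at 4 uM; a lower number here means that less of the compound is left, a higher number that more of the compound is left:
compound 1 `Cc1nc(N2CCN(C)CC2)c2nc(-c3ccccc3Cl)n(CCN3CCCC3=O)c2n1`: 28%
compound 2 `Cc1nc(N2CCN(C)CC2)c2nc(-c3ccccc3Cl)n(C3CC3)c2n1`: 44%
compound 3 `Cc1nc(N2CCN(C)CC2)c2nc(-c3ccccc3C(F)(F)F)n(C3CCOCC3)c2n1`: 38%

Compound 3, at 38%, lies within the scatter of both compound 2 and compound 1, so its place among the three is not resolved.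

The next compound is compound 4 `Cc1nc(N2CCN(C)CC2)c2nc(-c3ccccc3F)n(C3CCOCC3)c2n1`. The change is fluoro in place of trifluoromethyl on an aromatic carbon, with fluoro in place of trifluoromethyl on an aromatic carbon, ortho to a large group.

For the measured compounds named here, the only measured step is a number 16 percentage points higher from compound 1 to compound 2 (beyond the scatter). It replaces 2-(2-oxopyrrolidin-1-yl)ethyl with cyclopropyl on an aromatic nitrogen, a different place from the present change, so it gives only a rough idea of how far a single change can move this assay. Going by the values given here, no measured pair tests trifluoromethyl against fluoro. With no direct evidence, no shift beyond the scatter is expected. The expected step is a number 3 percentage points higher from compound 3 to compound 4 (within the scatter), a small rise that stays within the scatter. Compound 4 is estimated at 41%, with an expected range of 27% to 55%.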

Compound 4, percent of the compound remaining: 30%
Compound 4: middle estimate off by 11 percentage points, on the high side; low and high end bracket the measured number.
By their numbers in this assay, from the lowest: compounds 1, 4, 3 and 2 (each within the scatter of the next, the first and the last beyond it).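

In this assay, for the compounds shown here, going from 2-(trifluoromethyl)phenyl to 2-fluorophenyl gives a number 8 percentage points lower from compound 3 to compound 4 (within the scatter), the first reading of this position with the rest of the molecule held constant. On this pair, the exchange on an aromatic carbon, ortho to a large group, does not separate fluoro from trifluoromethyl in the percent of compound remaining. No measurement at hand offers an explanation for this result.

Going by these compounds alone, the chloro of compound 1 and compound 2 appears only with other groups on the aromatic nitrogen than the one shared by compound 3 and compound 4, so chloro cannot yet be compared directly with fluoro or trifluoromethyl. Also open, from the compounds shown here alone, is whether a methoxy or nitrile group at this position would move the number beyond the scatter from compound 3.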